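Swapping the aryl group on a dihydropyridine-like core

The source may hold more compounds than are shown below. What is called first, only, known or untested is meant among the compounds shown, and "the series" means these compounds.

Measured compounds:
compound 1 `COC(=O)C1=C(C)N=C(C)/C(=C(\O)OC)C1c1cccc(OC)c1` with 191 nM
compound 2 `COC(=O)C1=C(C)N=C(C)/C(=C(\O)OC)C1c1ccc(Cl)cc1` with 8130 nM
compound 3 `COC(=O)C1=C(C)N=C(C)/C(=C(\O)OC)C1c1cccc(C)c1` with 110 nM

All three share one core and differ only in the aryl group on a saturated ring carbon. In a functional assay (muscle tissue) with Cavia porcellus as the target (a higher number here means that more compound is needed for the effect, a lower number that less compound is needed), compound 2 gives 8130 nM, the highest of the three numbers, so it needs the most compound for the effect. Compound 1 stands a 43-fold higher number from compound 1 to compound 2 (1.63 log units; beyond the scatter) away in the other direction, and compound 3 even further: a 74-fold lower number from compound 2 to compound 3 (1.87 log units; beyond the scatter). The two neighbours, compound 1 and compound 3, are within the scatter of each other: a 1.7-fold lower number from compound 1 to compound 3 (0.24 log units; within the scatter).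

Compound 4 `COC(=O)C1=C(C)N=C(C)/C(=C(\O)OC)C1c1cccc(Cl)c1Cl` is not yet measured. It changes the same aryl group: 2,3-dichlorophenyl in place of 4-chlorophenyl on a saturated ring carbon.

The two steps that bear on this change are those that replaced the 4-chlorophenyl of compound 2, and both were large lowerings of the number. For the measured compounds named here, the new group in compound 4 keeps chlorine but in different positions, and no measured compound carries two chlorines, so the size is uncertain. Still, a large downward step is expected, a 140-fold lower number from compound 2 to compound 4 (2.13 log units; beyond the scatter). The estimate for compound 4 in this assay is 60 nM, with a range from 10 nM to 400 nM.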

Compound 4, half-maximal effective concentration: 19.1 nM
The estimate for compound 4 lay 3.1-fold (0.50 log units) above the measured number; the measured number falls inside the stated range.
By their numbers in this assay, from the lowest: compound 4; then compounds 3 and 1 (each within the scatter of the next); then compound 2.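

For the compounds shown here, the 2,3-dichlorophenyl group gives compound 4 the lowest number of the series in this assay, and all three of its steps lie beyond the scatter: the largest is the one from the 4-chlorophenyl group (a 430-fold lower number from compound 2 to compound 4 (2.63 log units; beyond the scatter)), while the steps from the other two are smaller (a 5.8-fold lower number from compound 3 to compound 4 (0.76 log units; beyond the scatter)) and (a 10-fold lower number from compound 1 to compound 4 (1.00 log units; beyond the scatter)). Until now, the only chlorine-bearing compound was the one needing the most compound for the effect, but compound 4 also carries chlorine and needs the least, so among these four compounds the presence of chlorine on the aryl group does not by itself go with a high number. The position on the saturated ring carbon can also reach a clearly lower number than compounds 1 and 3, which remain within the scatter of each other.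

Compound 4 differs from compound 2 in both the count and the places of its chlorines, so these compounds cannot separate those two changes, and they leave open how an aryl group carrying a nitro group or an amine would read here. Nothing available explains why the numbers move as they do.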